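A few compounds are considered here, and "the series" means these few. Any claim that something is new, unique, unknown or untested is made for them only; others in the source may bear on it.

Measured compounds in a functional assay on DLD-1 cells (Homo sapiens) for cytotoxicity, read by MTT assay; a lower number here means a stronger inhibitor, a higher number a weaker inhibitor:
compound 1, `CCOc1cc(/C=C/C(=O)C(=Cc2ccc(O)c(OC)c2)C(=O)/C=C/c2ccc(O)c(OCC)c2)ccc1O`, gives 9630 nM
compound 2, `CCOc1cc(C=C(C(=O)/C=C/c2ccc(O)c(OCC)c2)C(=O)/C=C/c2ccc(O)c(OCC)c2)ccc1O`, gives 1360 nM

Among the compounds with values here, compound 2 stands as the lower of the two numbers, with compound 1 as its only neighbour; the step of a 7.1-fold lower number from compound 1 to compound 2 (0.85 log units; beyond the scatter) separates them, and that step consists of a methyl in place of hydrogen on a saturated chain carbon bound to an oxygen on an aromatic ring.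

Compound 3, `CCOc1cc(/C=C/C(=O)C(=Cc2ccc(O)cc2)C(=O)/C=C/c2ccc(O)c(OCC)c2)ccc1O`, has not yet been measured. It differs from compound 2 in one place: hydrogen in place of ethoxy on an aromatic carbon. Within the data shown here, this change is of another kind than the one measured step. Neither compound 1 nor compound 2 lacks the ethoxy on the aromatic carbon, so the measured pair gives no direct reading of what removing it does. With nothing to calibrate against, the expectation for compound 3 is a step of a 1.8-fold higher number from compound 2 to compound 3 (0.26 log units; within the scatter) toward a somewhat higher number, though a result within the scatter of compound 2 cannot be excluded. Compound 3 is therefore estimated at 2500 nM, with a range from 800 nM to 8000 nM.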

Compound 3, half-maximal inhibitory concentration: 20300 nM
Compound 3: middle estimate off by 8.1-fold (0.91 log units), on the low side; measured number above the stated range.
By their numbers in this assay, from the lowest: compound 2; then compound 1; then compound 3.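

In this assay, the aromatic carbon ortho to a hydroxy group turns out not to be a neutral place, for removing the ethoxy there gives a 15-fold higher number from compound 2 to compound 3 (1.17 log units; beyond the scatter), while removing the methoxy from the same carbon gives a 2.1-fold higher number from compound 1 to compound 3 (0.32 log units; beyond the scatter). Together with a 7.1-fold lower number from compound 1 to compound 2 (0.85 log units; beyond the scatter), these steps place the three compounds in one order, with the number falling from hydrogen through methoxy to ethoxy at this carbon, and none of the three goes against that order; the earlier pair alone could not show that the bare 4-hydroxyphenyl group stands above both alkoxy versions, or that any oxygen-bearing group here gives a lower number than hydrogen. Nothing at hand explains why the group at this carbon matters so much.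

The three compounds leave open whether the order continues with a longer chain such as propoxy, or whether the oxygen or the carbon chain is what counts, which an ethyl group or an amine on the same carbon would help to separate. They also leave open whether the same change would act alike on the two other 3-ethoxy-4-hydroxyphenyl groups, which stay untouched throughout.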